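The compounds below may be only part of what the source reports. "The series", "measured", "known", "first", "only" and "open" are said of these compounds alone.

Measured so far in an ADME assay on microsomes from liver (Mus musculus) for metabolic stability, with a stated time of 10 min; on this read-out lower numbers stand for a less stable compound and higher numbers for a more stable compound:
- compound 1 `Cc1c(Cl)cccc1Oc1cccn2c(C3CCC(C)(O)CC3)nnc12`: 97%
- compound 2 `Cc1c(Cl)cccc1Oc1cccn2c(C3CCOCC3)nnc12`: 100%
- compound 3 `Cc1c(Cl)cccc1Oc1cccn2c(C3CCCCCC3O)nnc12`: 43%

Compound 3 stands lowest of the three, with both other compounds beyond the scatter above it. Compound 4 `Cc1c(Cl)cccc1Oc1cccn2c(C34CCC(F)(CC3)CC4)nnc12`, not yet measured, keeps the shared core and differs at one place: a group of 9 heavy atoms (8 carbon, 1 fluorine; 2 six-membered non-aromatic rings of carbon only) in place of a group of 8 heavy atoms (7 carbon, 1 oxygen; one seven-membered non-aromatic ring of carbon only), on an aromatic carbon.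

For the measured compounds named here, three measured steps bear on this, all at that same place. Two are large and lead into 2-hydroxycycloheptyl: a number 54 percentage points lower from compound 1 to compound 3 (beyond the scatter) and a number 57 percentage points lower from compound 2 to compound 3 (beyond the scatter). The third, a number 3 percentage points higher from compound 1 to compound 2 (within the scatter), exchanges the two other groups and stays within the scatter. The low reading so far therefore belongs to a single compound, the only one carrying 2-hydroxycycloheptyl, and compound 4 loses that group. Going by the values given here, no measured compound carries the entering group, however, so the high readings of compound 1 and compound 2 can only be carried over with caution.

A large upward step is expected, somewhat smaller than the two large steps seen so far. The expected step is a number 42 percentage points higher from compound 3 to compound 4 (beyond the scatter). For compound 4 the estimated value is 85%, with an expected range of 60% to 100%.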

Compound 4, percent of the compound remaining: 62%
Beside the measured number, compound 4's estimate is 23 percentage points above it; the range from low to high includes it.
By their numbers in this assay, from the lowest: compound 3; then compound 4; then compounds 1 and 2 (each within the scatter of the next).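

In this assay, losing 2-hydroxycycloheptyl from the aromatic carbon between two ring nitrogen atoms recovers only part of the high reading: the change gives a number 19 percentage points higher from compound 3 to compound 4 (beyond the scatter) as a modest gain, while the entering group still shows a number 38 percentage points lower from compound 2 to compound 4 (beyond the scatter) and a number 35 percentage points lower from compound 1 to compound 4 (beyond the scatter) as large drops. For the compounds shown here, the low reading at this position is therefore no longer confined to the one compound carrying 2-hydroxycycloheptyl, and the series now has three levels: compound 3 lowest, compound 4 in the middle, and compounds 1 and 2 together at the top, within the scatter of each other. Oxygen in the group does not sort these levels, as the groups of compound 1, compound 2 and compound 3 each hold one, yet they sit at both ends, and compound 4, whose group has none, falls between them.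

Going by these compounds, how an amine or a carboxylic acid on this carbon would read stays open, as does whether the fluorine or the two-ring carbon frame sets the reading of compound 4. Nothing shown gives a reason for any of these differences.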